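Bromo for chloro at the indole six-ring: an expected small step

This account rests on a few compounds, and the source may have more. Where it says the series, first, only, none or still open, it means among the compounds named here.

Compound 2 `CN1CCC(Sc2cn(C)c3ccc(Cl)cc23)CC1` gives 3.9 mg/kg in a functional assay on the whole organism with Mus musculus as the target, in the writhing test; on this read-out higher numbers stand for an effect only at larger amounts of compound and lower numbers for an effect already at smaller amounts. Compound 1 `CCOC(=O)N1CCC(Sc2c[nH]c3ccc(Br)cc23)CC1` gives 6.3 mg/kg in this assay, and the gap between compound 1 and compound 2 lies within the scatter, so neither stands apart. Compound 3 `CN1CCC(Sc2cn(C)c3ccc(Br)cc23)CC1` differs from compound 2 by bromo in place of chloro on an aromatic carbon. For the measured compounds named here, no measured pair shows this change alone. Compound 3 is expected to give 4 mg/kg in this assay, between 2 mg/kg and 8 mg/kg. The expected step of a 1.0-fold higher number from compound 2 to compound 3 (0.01 log units; within the scatter) is none beyond the scatter, in either direction.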

Compound 3, dose for half-maximal effect: 5.4 mg/kg
Estimate against measurement, compound 3: 1.4-fold (0.13 log units) below; measured number inside the range.
By their numbers in this assay, from the lowest: compounds 2, 3 and 1 (each within the scatter of the next).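

In this assay, for the compounds shown here, swapping the halogen alone on this aromatic carbon gives a 1.4-fold higher number from compound 2 to compound 3 (0.14 log units; within the scatter) and so offers the first direct reading of this change: at this place on the shared core, bromo and chloro cannot be told apart. Nothing available accounts for this result. The compounds shown stay with these two halogens at this place, so what a methoxy group, a nitrile or an amine on the same carbon would do remains open.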